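Trading an Ethyl Tail for a Hydroxylated Chain Terminus

The source may hold more compounds than are shown below. What is called first, only, known or untested is meant among the compounds shown, and "the series" means these compounds.

Measured so far:
compound 1, `C=CCc1cc(C(C)=O)c(O)cc1OCCCC#N`, giving 47% in an assay on isolated protein for inhibition of leukotriene B4 receptor 1 (Homo sapiens), tested at 10 uM; on this read-out lower numbers stand for less inhibition and higher numbers for more inhibition at the one concentration tested (going by the name of the read-out)
compound 2, `C=CCc1cc(C(C)=O)c(O)cc1OCCCCCCC`, giving 31%

Within the data shown here, compound 2 stands lowest of the two numbers in this assay; its nearest neighbour is compound 1, and the one measured step, a number 16 percentage points lower from compound 1 to compound 2 (beyond the scatter), separates them, a modest change beyond the scatter. Compound 3, `C=CCc1cc(C(C)=O)c(O)cc1OCCCCCC(C)(C)O`, has not yet been measured. It differs from compound 2 by 1-hydroxy-1-methylethyl in place of ethyl on a saturated chain carbon, five bonds along the chain from an oxygen on an aromatic ring. Among the measured compounds shown here, only the step of a number 16 percentage points lower from compound 1 to compound 2 (beyond the scatter) bears on this change, and only loosely: there, a cyano terminus gave way to a longer plain alkyl tail and inhibition fell, whereas here the tail keeps its length but its end acquires a hydroxyl. If the earlier step reflects the presence of an oxygen- or nitrogen-bearing terminus at all, compound 3 would be expected to recover part of the inhibition lost by compound 2, though the entering group is not the cyano of compound 1, so the expected step is tentative. Compound 3 is therefore expected to give 42%, within a range from 24% to 60%. That estimate corresponds to an expected step of a number 11 percentage points higher from compound 2 to compound 3 (beyond the scatter), a modest rise.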

Compound 3, a percentage reported as inhibition, at one concentration (the size of the read-out at that concentration, not a potency): 98%
Estimate against measurement, compound 3: 56 percentage points below, outside the stated range (above it).
By their numbers in this assay, from the lowest: compound 2; then compound 1; then compound 3.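

In this assay, among these compounds, placing 1-hydroxy-1-methylethyl where ethyl stood, on a saturated chain carbon, five bonds along the chain from an oxygen on an aromatic ring, gives a number 67 percentage points higher from compound 2 to compound 3 (beyond the scatter) and shows that this one change can move the read-out far more than the earlier compounds suggested. The change also carries the series past the level set by the nitrile: 3-hydroxy-3-methylbutyl in place of cyano gives a number 51 percentage points higher from compound 1 to compound 3 (beyond the scatter) and so does more than restore what the plain alkyl tail of compound 2 had lost. Among the compounds shown here, compound 3 is therefore the highest of the three in this assay, and both of its large steps outsize the modest a number 16 percentage points lower from compound 1 to compound 2 (beyond the scatter) that was the only guide to this part of the molecule before.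

Going by these compounds, the change brings in the hydroxyl and the two methyl groups together, so it remains open whether a tert-butyl group, a primary alcohol, a methyl ether, a carboxylic acid or an amine at the same place would give a similar number, and these are single-concentration readings that give no potency. Nothing presented here offers any measured explanation of the rise.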